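The source may hold more compounds than are shown below. What is called first, only, known or untested is meant among the compounds shown, and "the series" means these compounds.

Measured so far:
compound 1, `CN(C(=O)CC(CC(=O)NCCN1CCCC1)c1ccccc1)C1Cc2ccccc2C1`: > 100000 nM
compound 2, `CN(C(=O)CC(CC(=O)NCCN1CCCC1)c1ccc(Cl)cc1)C1Cc2ccccc2C1`: 81500 nM
compound 3, `CCNCCNC(=O)CC(CC(=O)N(CC)C1Cc2ccccc2C1)c1ccc(Cl)cc1`: 66200 nM

Of the compounds shown here, three have been tested in a functional assay on L02 cells (Homo sapiens) for inhibition; on this read-out lower numbers stand for stronger inhibition and higher numbers for weaker inhibition. For compound 1 the result is a limit of the assay rather than a number: compound 1 gives > 100000 nM. Compound 2 carries a chloro group where compound 1 carries a hydrogen, and in this assay compound 2 gives 81500 nM. Compound 3 is built on a different core, and how the core of compound 3 differs from the core of compound 2 is not broken down here. In this assay compound 3 gives 66200 nM, a number that lies within the usual scatter of the number for compound 2.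

One structural change occurs twice among these compounds. From compound 2 to compound 1 it reads hydrogen in place of chloro on an aromatic carbon and it produced an at least 1.2-fold higher number from compound 2 to compound 1 (0.08 log units; that floor lies within the scatter). Because compound 1 sits at the limit of > 100000 nM in this assay, at which 1 of the 3 values shown sits, only a floor for that step is known. From compound 3 to compound 4, `CCNCCNC(=O)CC(CC(=O)N(CC)C1Cc2ccccc2C1)c1ccccc1`, the same change is made, in the same place word for word: hydrogen in place of chloro on an aromatic carbon.

For compound 4 the step is expected to be a 1.4-fold higher number from compound 3 to compound 4 (0.16 log units; within the scatter). That expectation rests on compound 3 giving 66200 nM and on the size of an at least 1.2-fold higher number from compound 2 to compound 1 (0.08 log units; that floor lies within the scatter). Compound 4 is therefore estimated to give about 95000 nM, between 50000 nM and 200000 nM, with a real chance that the assay returns only a limit.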

Compound 4, half-maximal inhibitory concentration: > 100000 nM
Compound 4: a limit, no number; the forecaster's own chance of this, stated with the estimate: 45%; middle value at least 1.0-fold (0.02 log units) from the limit.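

In this assay compound 4 gives > 100000 nM as a limit of the assay, not as a number. The change from 4-chlorophenyl to phenyl therefore yields only a floor, an at least 1.5-fold higher number from compound 3 to compound 4 (0.17 log units; that floor lies within the scatter), and that floor can be set beside the one on the other core: the same change on two cores in this assay, an at least 1.2-fold higher number (0.08 log units; that floor lies within the scatter) from compound 2 to compound 1 and an at least 1.5-fold higher number (0.17 log units; that floor lies within the scatter) from compound 3 to compound 4; the limit leaves it open whether they differ. On each core the compound with the 4-chlorophenyl group returns a number and the compound with the phenyl group returns a limit, which is a shared outcome, but neither floor lies beyond the scatter, so this does not show that the change has a real effect on either core or an effect of the same size on both, and the ceiling of the assay hides how far each phenyl compound actually lies: the limit of > 100000 nM in this assay, at which 2 of the 4 values shown sit.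

The compounds shown leave open how a different group at the same place on the ring, such as fluoro, methoxy or trifluoromethyl, would read in this assay. They also leave open whether a longer chain on the amide nitrogen, or a different amine at the end of the side chain, would bring the numbers clear of the limit, so that a change like this one could be sized.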